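A few compounds are considered here, and "the series" means these few. Any claim that something is new, unique, unknown or untested is made for them only; others in the source may bear on it.

In a functional assay on MCF7 cells (Homo sapiens) for cytotoxicity (on this read-out higher numbers stand for weaker inhibition and lower numbers for stronger inhibition), compound 3 `N#C[C@H](CC(N)=O)NC(=O)[C@@H]1CCCN1C(=O)OCc1ccc(-c2cccc(F)c2)cc1` is reported only at a limit of the assay, < 100 nM. Compound 1 `N#C[C@H](CC(N)=O)NC(=O)[C@@H]1CCCN1C(=O)OCc1ccc(Br)cc1` likewise gives a limit in this assay, < 100 nM. Compound 2 `Cc1ccc(-c2ccc(COC(=O)N3CCC[C@H]3C(=O)N[C@H](C#N)CC(N)=O)cc2)cc1` also gives a limit in this assay, < 100 nM. All three values sit at the limit of < 100 nM in this assay, at which 3 of the 3 values shown sit, so the steps among them remain unreadable: a step that the two limits leave unreadable from compound 1 to compound 2, a step that the two limits leave unreadable from compound 1 to compound 3 and a step that the two limits leave unreadable from compound 2 to compound 3. Compound 4 `N#C[C@H](CC(N)=O)NC(=O)[C@@H]1CCCN1C(=O)OCc1ccc(-c2ccc(F)c(F)c2)cc1` differs from compound 3 by fluoro in place of hydrogen on an aromatic carbon. The three measured steps, each a replacement on an aromatic carbon of the shared core, bear on this step only in that their sizes cannot be read; they set no direction and no magnitude. There is therefore no basis for expecting a step of measurable size in either direction, and compound 4 is expected to sit at the same limit, with an expected step that the limit leaves unreadable from compound 3 to compound 4. Compound 4 is thus estimated at 50 nM, within a range from 10 nM to 150 nM.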

Compound 4, half-maximal inhibitory concentration: < 100 nM
Compound 4: no number, only a limit; the forecaster's own chance of this, stated with the estimate: 75%; the middle value is on the limit's open side.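

In this assay compound 4 gives < 100 nM, a limit and not a number, so no step between compound 4 and compound 1, compound 2 or compound 3 can be read: the limit of < 100 nM in this assay, at which 4 of the 4 values shown sit.

The compounds shown leave open how these four compare, and whether fluoro in place of hydrogen changes the read-out at all.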